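Phenyl addition in a weak amide series

This account rests on a few compounds, and the source may have more. Where it says the series, first, only, none or still open, it means among the compounds named here.

- compound 1 `O=C(Nc1cccc(OCc2ccc(-c3ccccc3)cc2)c1)C1CCCNC1` gives 153000 nM here
- compound 2 `O=C(Nc1cccc(OCc2ccccc2)c1)C1CCNCC1` gives 229000 nM here

Within the data shown here, both values come from a functional assay on a cell-free system (Platelet, plasma, Homo sapiens) for inhibition (a lower number here means a stronger inhibitor, a higher number a weaker inhibitor), and lie within the scatter of each other, so compound 2 has no clear separation from compound 1 on the numbers so far. Compound 3 `O=C(Nc1cccc(OCc2ccc(-c3ccccc3)cc2)c1)C1CCNCC1` is compound 2 with phenyl in place of hydrogen on an aromatic carbon, para to a large group (phenyl in place of hydrogen on an aromatic carbon). Among the measured compounds shown here, no measured pair isolates this change. For the measured compounds named here, compound 1 also carries such a phenyl and gives 153000 nM in this assay, which is the only guide available. The estimated change is a 1.9-fold lower number from compound 2 to compound 3 (0.28 log units; within the scatter) and is expected to be a small move toward a lower number, not beyond the scatter. For compound 3 the estimate is 120000 nM, with an expected range from 40000 nM to 300000 nM in this assay.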

Compound 3, half-maximal inhibitory concentration: 111000 nM
Compound 3: the middle estimate sits 1.1-fold (0.03 log units) above what was measured; measured number inside the range.
By their numbers in this assay, from the lowest: compounds 3, 1 and 2 (each within the scatter of the next, the first and the last beyond it).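

Phenyl in place of hydrogen on an aromatic carbon, para to a large group, now has a direct pair: in this assay the change gives a 2.1-fold lower number from compound 2 to compound 3 (0.31 log units; beyond the scatter), a modest step that only just clears the scatter. The position therefore accepts the added aromatic ring with no loss, which compound 1 alone could not show, as it differs from compound 2 in two places. Piperidin-4-yl in place of piperidin-3-yl on a carbonyl carbon gives a 1.4-fold lower number from compound 1 to compound 3 (0.14 log units; within the scatter), a change that cannot be told from none, and nothing available explains either step.

Open, as far as these compounds go, is whether the step is specific to phenyl or would also appear with a methyl group, a chlorine atom or a pyridyl ring in the same place. Also open is whether the phenyl step holds with piperidin-3-yl, since compound 1 has no partner shown without the phenyl.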